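Para substituent swap on the cinnamamide aryl ring

The source may hold more compounds than are shown below. What is called first, only, known or untested is meant among the compounds shown, and "the series" means these compounds.

Compound 1 `CCCc1cc(N)c2cc(NC(=O)/C=C/c3ccc(F)cc3)ccc2n1` gives 130 nM in an assay on isolated protein for displacement of a labelled ligand from melanin-concentrating hormone receptor 1 (Homo sapiens) (a lower number here means a stronger inhibitor, a higher number a weaker inhibitor), the highest number of the three measured here. For the measured compounds named here, compound 2 `CC(C)(C)c1cc(N)c2cc(NC(=O)/C=C/c3ccc(C(F)(F)F)cc3)ccc2n1` gives 0.3 nM in this assay, and compound 3 `CCCc1cc(N2CCC2)c2cc(NC(=O)/C=C/c3ccc(C(F)(F)F)cc3)ccc2n1` gives 2.8 nM; both differ from compound 1 in more than one place, so no single step is available, and their lower numbers go with a trifluoromethyl on the aromatic carbon where compound 1 carries fluoro.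

Compound 4 `CCCc1cc(N)c2cc(NC(=O)/C=C/c3ccc(C(C)C)cc3)ccc2n1` is not yet measured. It differs from compound 1 by isopropyl in place of fluoro on an aromatic carbon, para to a large group. Going by the values given here, no directly comparable step is known. Beyond the scatter but short of what compound 2 shows, a move toward a lower number of moderate size is expected for compound 4: the estimated step is an 11-fold lower number from compound 1 to compound 4 (1.03 log units; beyond the scatter). Compound 4 is estimated at 12 nM, within 2.5 nM to 60 nM.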

Compound 4, half-maximal inhibitory concentration: 2.9 nM
Beside the measured number, compound 4's estimate is 4.1-fold (0.62 log units) above it; the range from low to high includes it.
By their numbers in this assay, from the lowest: compound 2; then compounds 3 and 4 (each within the scatter of the next); then compound 1.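

For the compounds shown here, this is the first step that changes only the group on this aromatic carbon: isopropyl in place of fluoro gives a 45-fold lower number from compound 1 to compound 4 (1.65 log units; beyond the scatter) in this assay. With the rest of compound 1 held fixed, this change alone moves the number by a large amount, which compounds 2 and 3 could not show because they differ in more than one place. Neither group carries a hydrogen-bond donor or acceptor, so the step does not depend on adding either one. No available evidence bears on the reason for this step.

Still open, as far as these compounds go, is how methyl, methoxy or a carboxylic acid would read on this carbon. Also open, from the compounds shown here alone, is whether the step carries over to the other substituents of compounds 2 and 3.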